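The source may hold more compounds than are shown below. What is called first, only, known or untested is meant among the compounds shown, and "the series" means these compounds.

Measured in a functional assay on the whole organism with Rattus norvegicus as the target; on this read-out higher numbers stand for an effect only at larger amounts of compound and lower numbers for an effect already at smaller amounts:
- Compound 1 `CCOC(=O)C(=O)Nc1ccc(N)cc1C#N`: 8.8 mg/kg
- Compound 2 `CCOC(=O)C(=O)Nc1cccc(NC)c1C#N`: 0.1 mg/kg
- Compound 3 `CNc1cccc(NC(=O)C(=O)O)c1C#N`: 0.07 mg/kg

Compound 2, at 0.1 mg/kg, lies within the scatter of compound 3 and well under compound 1. Compound 4 `CCOC(=O)C(=O)Nc1cccc(N(CC)CC)c1C#N` remains unmeasured. It carries diethylamino in place of methylamino on an aromatic carbon, ortho to a cyano group: diethylamino in place of methylamino on an aromatic carbon. Within the data shown here, the only measured step, a 1.4-fold lower number from compound 2 to compound 3 (0.15 log units; within the scatter), swaps ethyl for hydrogen on an oxygen and leaves the amino group untouched, so it offers no direct guide. Compound 1, at 8.8 mg/kg, shows only that numbers among these compounds can lie far higher, and it is no clean comparison. A moderate rise is therefore expected, estimated as a 4.0-fold higher number from compound 2 to compound 4 (0.60 log units; beyond the scatter). For compound 4 the expected value is 0.4 mg/kg, with an estimated range of 0.06 mg/kg to 3 mg/kg.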

Compound 4, dose for half-maximal effect: 0.9 mg/kg
Beside the measured number, compound 4's estimate is 2.3-fold (0.35 log units) below it, and the stated range covers the measured number.
By their numbers in this assay, from the lowest: compounds 3 and 2 (each within the scatter of the next); then compound 4; then compound 1.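

In this assay, the group on the aromatic carbon ortho to a cyano group proves sensitive to change, as diethylamino in place of methylamino gives a step beyond the scatter (a 9.0-fold higher number from compound 2 to compound 4 (0.95 log units; beyond the scatter)). This change takes the group from 2 to 5 heavy atoms and from 1 hydrogen-bond donor to 0, and the compounds cannot separate these two differences. Nothing measured here explains the step. Ethylamino, dimethylamino or a plain amine at this place could show which difference counts. As far as these compounds go, whether diethylamino behaves the same way alongside the carboxylic acid of compound 3 also stays open.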